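A few compounds are considered here, and "the series" means these few. Any claim that something is new, unique, unknown or untested is made for them only; others in the source may bear on it.

Compound 3, `Cc1c2c(n3c1CC(=O)N(CCN(C)C)CC[C@H](C)Nc1cc-3ccc1C(N)=O)CC(C)(C)CC2=O`, belongs to a small set of analogues that share one core and differ in the chain that closes the large ring. In a functional assay on HCT-116 cells (Homo sapiens) for antiproliferative activity (on this read-out lower numbers stand for an effect already at smaller amounts and higher numbers for an effect only at larger amounts of compound), compound 3 gives 330 nM, the higher of the two numbers recorded in this assay. Compound 1, `Cc1c2c(n3c1CCCNC[C@H](C)Nc1cc-3ccc1C(N)=O)CC(C)(C)CC2=O`, gives 93 nM in this assay, and the gap to compound 3 lies beyond the usual scatter. Compound 2, `Cc1c2c(n3c1CC(=O)NCCCNc1cc-3ccc1C(N)=O)CC(C)(C)CC2=O`, shows "not determined" (no result reported) in this assay, so it adds nothing to the comparison.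

Compound 4, `Cc1c2c(n3c1CC(=O)N(C)CC[C@H](C)Nc1cc-3ccc1C(N)=O)CC(C)(C)CC2=O`, differs from compound 3 in a single place: hydrogen in place of (dimethylamino)methyl on a saturated chain carbon bound to an amide-type nitrogen in a ring. No measured pair in this set carries that same change, so the numbers shown give no direct guide to its size or direction. The chain that is shortened sits on the amide-type nitrogen in the ring, away from the part of the core that compound 1 and compound 3 hold in common.

The step is expected to be modest, a 1.3-fold lower number from compound 3 to compound 4 (0.12 log units; within the scatter), most likely within the scatter or a small move toward a lower number. Compound 4 is therefore estimated at 250 nM in this assay, with a range from 80 nM to 800 nM.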

Compound 4, half-maximal effective concentration in the HCT-116 assay: 247 nM
Compound 4: middle estimate off by 1.0-fold (0.01 log units), on the high side; the range from low to high includes it.
By their numbers in the HCT-116 assay, from the lowest: compound 1; then compounds 4 and 3 (each within the scatter of the next).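

In the HCT-116 assay, hydrogen in place of (dimethylamino)methyl on a saturated chain carbon bound to an amide-type nitrogen in a ring amounts to a 1.3-fold lower number from compound 3 to compound 4 (0.13 log units; within the scatter), which gives this position its first direct reading: on this read-out, the shift from 2-(dimethylamino)ethyl to methyl does not separate the two compounds. In a physicochemical assay for solubility (a higher number here means a more soluble compound, a lower number a less soluble compound), compound 3 gives > 100 ug/mL, which is a limit of the assay and not a number. In the physicochemical assay, compound 4 gives > 100 ug/mL, which is likewise a limit of the assay.

The step between these two compounds in the physicochemical assay cannot be read, so the solubility effect of this change remains unknown, as both results stop at the same limit: the limit of > 100 ug/mL in the physicochemical assay, at which 2 of the 2 values shown sit.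

Also open, from the compounds shown here alone, is how a carboxylic acid, a primary amine or a longer chain carrying the dimethylamino group would read at this place in the HCT-116 assay, since the two compounds compared here cover only the 2-(dimethylamino)ethyl and methyl groups.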